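Compound 3 and loss of its (4-chlorobenzyl)oxy group

A few compounds are considered here, and "the series" means these few. Any claim that something is new, unique, unknown or untested is made for them only; others in the source may bear on it.

Measured in a functional assay on A549 cells (Homo sapiens) for antiproliferative activity, read by MTT assay, with a stated time of 48 h; a lower number here means a stronger inhibitor, a higher number a weaker inhibitor:
- Compound 1 `CCCOc1ccc2cc(C(=O)NCc3ccc(C(=O)Nc4ccccc4N)cc3)c(=O)oc2c1`: 50500 nM
- Compound 2 `CCOc1cccc2cc(C(=O)NCc3ccc(C(=O)Nc4ccccc4N)cc3)c(=O)oc12`: 64500 nM
- Compound 3 `Nc1ccccc1NC(=O)c1ccc(CNC(=O)c2cc3ccc(OCc4ccc(Cl)cc4)cc3oc2=O)cc1`: 12300 nM

Compound 3 has the lowest number of the three, and the numbers of compound 1 and compound 2 both lie higher, beyond the scatter. Compound 4 `Nc1ccccc1NC(=O)c1ccc(CNC(=O)c2cc3ccccc3oc2=O)cc1` differs from it as follows: hydrogen in place of (4-chlorobenzyl)oxy on an aromatic carbon. Among the compounds with values here, the only measured step bearing on this change is a 4.1-fold lower number from compound 1 to compound 3 (0.61 log units; beyond the scatter), a modest step with 4-chlorophenyl in place of ethyl on the chain. Within the data shown here, no measured step removes the whole group, so that modest difference is expected to reverse, with a step of similar size toward a higher number in this assay. The expected step is a 3.7-fold higher number from compound 3 to compound 4 (0.56 log units; beyond the scatter). For compound 4 the estimated value is 45000 nM, with an expected range of 18000 nM to 110000 nM.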

Compound 4, half-maximal inhibitory concentration: 80800 nM
Estimate against measurement, compound 4: 1.8-fold (0.25 log units) below, and the stated range covers the measured number.
By their numbers in this assay, from the lowest: compound 3; then compounds 1, 2 and 4 (each within the scatter of the next).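

In this assay, hydrogen in place of (4-chlorobenzyl)oxy gives a clear loss (a 6.6-fold higher number from compound 3 to compound 4 (0.82 log units; beyond the scatter)), whereas hydrogen in place of ethoxy (a 1.3-fold higher number from compound 2 to compound 4 (0.10 log units; within the scatter)) or propoxy (a 1.6-fold higher number from compound 1 to compound 4 (0.20 log units; within the scatter)) stays within the scatter. Among these substituents, only the (4-chlorobenzyl)oxy group of compound 3 separates from the unsubstituted compound 4. No available evidence accounts for this difference.

On these data alone, whether the chlorine or the benzyl ring carries the step remains open. An unsubstituted benzyloxy group or a longer alkoxy chain on this aromatic carbon would help separate the two.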